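This account rests on a few compounds, and the source may have more. Where it says the series, first, only, none or still open, it means among the compounds named here.

Three related compounds were tested in a functional assay on HT-1080 cells (Homo sapiens), read by transwell migration, with a stated time of 24 h, tested at 1 uM; a higher number here means a weaker effect of the compound at the concentration tested, a lower number a stronger effect. Compound 1 `O=C(Oc1cccc(Br)c1)c1cc2cc([N+](=O)[O-])ccc2oc1=O` gives 35.2% in this assay. Compound 2 `O=C(Oc1cccc(I)c1)c1cc2cc([N+](=O)[O-])ccc2oc1=O` shares its core but carries iodo in place of bromo on an aromatic carbon; in this assay compound 2 gives 63.6%, and the step of a number 28.4 percentage points higher from compound 1 to compound 2 (beyond the scatter) is beyond the scatter. Compound 3 `NCc1ccc2oc(=O)c(C(=O)Oc3cccc(Br)c3)cc2c1` differs from compound 1 in its core by aminomethyl in place of nitro on an aromatic carbon; in this assay compound 3 gives 79.3%, the highest of the three numbers, and the step of a number 44.1 percentage points higher from compound 1 to compound 3 (beyond the scatter) is beyond the scatter as well.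

Compound 4 `NCc1ccc2oc(=O)c(C(=O)Oc3cccc(I)c3)cc2c1` has not yet been measured in this assay. It is related to compound 3 by iodo in place of bromo on an aromatic carbon. This is the same change that turns compound 1 into compound 2, made at a place described in the same words for both pairs, so the earlier step is the nearest guide. Because that step was a number 28.4 percentage points higher from compound 1 to compound 2 (beyond the scatter), a rise of similar size from compound 3 is expected, though compound 3 already sits high and the step could be smaller. The expected step for compound 4 is a number 13.7 percentage points higher from compound 3 to compound 4 (beyond the scatter). Compound 4 is estimated to give 93% in this assay, likely between 78% and 108%.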

Compound 4, a percentage reported as activity, at one concentration (the size of the read-out at that concentration, not a potency): 25.3%
The estimate for compound 4 lay 67.7 percentage points above the measured number; the measured number lies below the stated range.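

On the aminomethyl compounds, iodo in place of bromo gives a number 54 percentage points lower from compound 3 to compound 4 (beyond the scatter), which means a stronger effect in this assay and runs opposite to the same change on the nitro compounds: the same change on two cores in this assay, a number 28.4 percentage points higher (beyond the scatter) from compound 1 to compound 2 and a number 54 percentage points lower (beyond the scatter) from compound 3 to compound 4, 82.4 percentage points apart, beyond the scatter of two such steps
Seen from the other side, aminomethyl in place of nitro gives a number 38.3 percentage points lower from compound 2 to compound 4 (beyond the scatter), whereas the same change on the 3-bromophenyl compounds raised the number: the same change on two cores in this assay, a number 44.1 percentage points higher (beyond the scatter) from compound 1 to compound 3 and a number 38.3 percentage points lower (beyond the scatter) from compound 2 to compound 4, 82.4 percentage points apart, beyond the scatter of two such steps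
These steps show that, among these four compounds, the result of each change depends on the group present elsewhere, so a step from one core cannot simply be carried to another; they do not show why this happens or whether it holds beyond these compounds.

The compounds shown leave open whether the reversal is tied to aminomethyl itself or would also appear with a longer aminoethyl chain or a carboxylic acid in its place, and whether chloro in place of bromo would behave like bromo or like iodo. From the compounds shown here alone, each number is also a reading at one concentration, so it gives the size of the effect at that concentration only, and how the four compounds compare at other concentrations remains open.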